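This account rests on a few compounds, and the source may have more. Where it says the series, first, only, none or still open, it means among the compounds named here.

Measured compounds:
- compound 1 `CCOc1ccc2sc(S(C)(=O)=O)nc2c1S(=O)(=O)NC(C)(C)C`: 76600 nM
- compound 2 `CCOc1ccc2sc(S(C)(=O)=O)nc2c1S(=O)(=O)Nc1ccc(Br)cc1`: 74500 nM

These two compounds share one core and differ only in the group on the sulfonamide nitrogen. In a functional assay on HeLa cells (Homo sapiens) for inhibition, read by sulforhodamine B assay, with a stated time of 48 h (a higher number here means that more compound is tolerated, a lower number that less compound is tolerated), compound 1 gives 76600 nM and compound 2 gives 74500 nM. The step of a 1.0-fold lower number from compound 1 to compound 2 (0.01 log units; within the scatter) shows that replacing tert-butyl by 4-bromophenyl left the number essentially where it was, so compound 2 and compound 1 sit together within the scatter, and compound 2 stands apart from nothing.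

Compound 3 `CCOc1ccc2sc(S(C)(=O)=O)nc2c1S(=O)(=O)NC(CC)CC` has not been measured. It differs from compound 2 by pentan-3-yl in place of 4-bromophenyl on a sulfonamide nitrogen. Among the measured compounds shown here, the only step that bears on this is a 1.0-fold lower number from compound 1 to compound 2 (0.01 log units; within the scatter), which exchanged one sulfonamide substituent for another without effect beyond the scatter. A second exchange at the same nitrogen is therefore expected to give no step beyond the scatter, namely a 1.0-fold higher number from compound 2 to compound 3 (0.01 log units; within the scatter). For compound 3 in this assay the estimate is 76000 nM, with a range from 32000 nM to 180000 nM.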

Compound 3, concentration lethal to 50% of the cells: 87400 nM
Estimate against measurement, compound 3: 1.2-fold (0.06 log units) below; the measured number falls inside the stated range.
By their numbers in this assay, from the lowest: compounds 2, 1 and 3 (each within the scatter of the next).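

In this assay, the step of a 1.2-fold higher number from compound 2 to compound 3 (0.07 log units; within the scatter) shows that pentan-3-yl, which has no ring, can replace 4-bromophenyl on the sulfonamide nitrogen without a difference that can be read, and the step of a 1.1-fold higher number from compound 1 to compound 3 (0.06 log units; within the scatter) shows the same for pentan-3-yl against tert-butyl. Among the compounds shown here, the single earlier step compared only two groups, whereas three now sit together within the scatter, one with an aromatic ring and a bromine and two with no ring. No measurement in hand explains why these exchanges at this nitrogen leave the number in place.

Left open is whether an amine or a carboxylic acid carried on this nitrogen would also leave the number in place. The rest of the core is the same in all three compounds, so they cannot tell what a change elsewhere would do.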